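This account rests on a few compounds, and the source may have more. Where it says the series, first, only, none or still open, it means among the compounds named here.

Of the compounds shown here, three with a shared core have numbers so far in a functional assay on MDA-MB-231 cells (Homo sapiens) for antiproliferative activity, read by MTT assay, with a stated time of 48 h (a lower number here means a stronger inhibitor, a higher number a weaker inhibitor), and all of them sit in a narrow band. Compound 1 (`CN1CCN(c2ccc(-c3cc4c(N5CCN(S(=O)(=O)C6CC6)CC5)ncnc4s3)cc2)CC1`) gives 11500 nM there, compound 2 (`CN1CCN(c2ccc(-c3cc4c(N5CCN(C(=O)Nc6ccc(Cl)cc6)CC5)ncnc4s3)cc2)CC1`) gives 5440 nM there and compound 3 (`CN1CCN(c2ccc(-c3cc4c(N5CCN(C(=O)Nc6ccc(OC(F)(F)F)cc6)CC5)ncnc4s3)cc2)CC1`) gives 4600 nM there. Compound 3 thus sits with compound 2 at the low end of this small set, the two lying within the scatter of each other, while compound 1 stands higher than both. The next compound, compound 4 (`CN1CCN(c2ccc(-c3cc4c(N5CCN(C(=O)Nc6cccc(F)c6)CC5)ncnc4s3)cc2)CC1`), carries 3-fluorophenyl in place of 4-(trifluoromethoxy)phenyl on an amide-type nitrogen. The closest evidence is a 1.2-fold lower number from compound 2 to compound 3 (0.07 log units; within the scatter) for trifluoromethoxy in place of chloro on an aromatic carbon, a change that stayed within the scatter. Going by the values given here, the only step beyond the scatter is a 2.1-fold lower number from compound 1 to compound 2 (0.33 log units; beyond the scatter) for the much larger exchange of (4-chlorophenyl)carbamoyl in place of cyclopropylsulfonyl, and it is modest. Among the compounds with values here, none of the measured compounds carries 3-fluorophenyl, so this remains an extrapolation. The expected change is small and slightly upward, with a 1.3-fold higher number from compound 3 to compound 4 (0.12 log units; within the scatter) as the estimate, which would leave it within the scatter. For compound 4 the estimated value is 6000 nM with an expected range from 3000 nM to 12000 nM in this estimate.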

Compound 4, half-maximal inhibitory concentration: 13200 nM
Beside the measured number, compound 4's estimate is 2.2-fold (0.34 log units) below it, outside the stated range (above it).
By their numbers in this assay, from the lowest: compounds 3 and 2 (each within the scatter of the next); then compounds 1 and 4 (each within the scatter of the next).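

In this assay, the aryl group on this amide-type nitrogen proves able to move the number beyond the scatter, though only modestly: 3-fluorophenyl gives a 2.9-fold higher number from compound 3 to compound 4 (0.46 log units; beyond the scatter) and, against 4-chlorophenyl, a 2.4-fold higher number from compound 2 to compound 4 (0.38 log units; beyond the scatter), whereas the exchange between the two 4-substituted groups had given only a 1.2-fold lower number from compound 2 to compound 3 (0.07 log units; within the scatter). The earlier advantage of the arylcarbamoyl groups over cyclopropylsulfonyl also proves not to hold for every aryl group, since 3-fluorophenyl gives a 1.1-fold higher number from compound 1 to compound 4 (0.06 log units; within the scatter), so that the step from compound 1 to compound 2 cannot be read as belonging to the carbamoyl link alone. No measurement offered here accounts for the rise seen with 3-fluorophenyl.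

The compounds shown leave open whether that rise follows the fluorine itself or its place on the ring, a question that 4-fluorophenyl and 3-chlorophenyl on the same nitrogen would separate. They also leave open how unsubstituted phenyl would read here, and whether an amine or a carboxylic acid on that ring could bring the number below those of compound 2 and compound 3.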